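The source may report more compounds than this note shows. Statements on the series, on what has been measured and on what is new or still open speak of the compounds shown alone.

Measured in a functional assay on Bel-7402 cells (Homo sapiens) for antiproliferative activity, read by MTT assay, with a stated time of 72 h; a lower number here means a stronger inhibitor, a higher number a weaker inhibitor:
- compound 1 `COc1ccc(Cn2c(C(=O)O)c(CNCc3cc(OC)ccc3O)c3ccc(C)cc32)cc1`: > 50000 nM (a limit)
- compound 2 `COc1ccc(Cn2c(C(=O)O)c(CNCc3cccc(O)c3)c3ccc(C(C)C)cc32)cc1`: 9270 nM
- compound 3 `COc1ccc(Cn2c(C(=O)O)c(CNCc3ccc(O)c(OC)c3)c3ccc(C)cc32)cc1`: 13300 nM

Compound 3, at 13300 nM, lies within the scatter of compound 2 at 9270 nM. Compound 1 sits at a limit, (the limit of > 50000 nM in this assay, at which 1 of the 3 values shown sits).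

Compound 4 `COc1ccc(Cn2c(C(=O)O)c(CNCc3cccc(O)c3)c3ccc(C)cc32)cc1` carries 3-hydroxyphenyl in place of 4-hydroxy-3-methoxyphenyl on a saturated chain carbon bound to an amine nitrogen. Among the measured compounds shown here, the one measured step at this place, an at least 3.7-fold lower number from compound 1 to compound 3 (0.57 log units; beyond the scatter), starts from a limit, so it shows that the place can respond but gives no size for this change. Compound 2 gives 9270 nM with the same 3-hydroxyphenyl, on a core that differs from that of compound 4. The expected change in this assay is small and within the scatter, a 1.1-fold lower number from compound 3 to compound 4 (0.04 log units; within the scatter). Compound 4 is estimated at 12000 nM, with an expected range of 5500 nM to 30000 nM.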

Compound 4, half-maximal inhibitory concentration: 19800 nM
Beside the measured number, compound 4's estimate is 1.7-fold (0.22 log units) below it; low and high end bracket the measured number.
By their numbers in this assay, from the lowest: compounds 2, 3 and 4 (each within the scatter of the next, the first and the last beyond it). At a limit, above all of these: compound 1.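

In this assay, 3-hydroxyphenyl in place of 4-hydroxy-3-methoxyphenyl on a saturated chain carbon bound to an amine nitrogen gives a 1.5-fold higher number from compound 3 to compound 4 (0.17 log units; within the scatter), so this change does not separate the two groups. With 3-hydroxyphenyl held, methyl in place of isopropyl on an aromatic carbon gives a 2.1-fold higher number from compound 2 to compound 4 (0.33 log units; beyond the scatter), a modest step at a second place. The 2-hydroxy-5-methoxyphenyl of compound 1 remains apart, an at least 2.5-fold lower number from compound 1 to compound 4 (0.40 log units; beyond the scatter), but this step gives only a minimum size, as compound 1 stands at a limit: the limit of > 50000 nM in this assay, at which 1 of the 4 values shown sits.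

Still open, going by these compounds, is how the aromatic carbon responds to a chlorine or a longer chain. Also open, on these data alone, is the effect of an amide or ester in place of the carboxylic acid.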